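Hydroxy versus 2-aminophenyl on the amide nitrogen

A few compounds are considered here, and "the series" means these few. Any claim that something is new, unique, unknown or untested is made for them only; others in the source may bear on it.

Compound 1 `CC(C)(C)OC(=O)Nc1cccc(-c2csc(NC(=O)CCCCCC(=O)NO)n2)c1`: 2580 nM
Compound 2 `CC(C)(C)OC(=O)Nc1cccc(-c2csc(NC(=O)CCCCCC(=O)Nc3ccccc3N)n2)c1`: > 30000 nM (a limit)
Compound 3 `CCOC(=O)Nc1cccc(-c2csc(NC(=O)CCCCCC(=O)Nc3ccccc3N)n2)c1`: > 30000 nM (a limit)

Measurements are from an assay on isolated protein for inhibition of histone deacetylase 8 (Homo sapiens), read by fluorescence, with a stated time of 17 h; a lower number here means a stronger inhibitor, a higher number a weaker inhibitor. Compound 1 gives 2580 nM. Compound 2 gives only the limit > 30000 nM. Compound 3 also gives only the limit > 30000 nM, so it stands at the limit of > 30000 nM in this assay, at which 2 of the 3 values shown sit, and its true position is not readable from the numbers shown.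

Compound 4 `CCOC(=O)Nc1cccc(-c2csc(NC(=O)CCCCCC(=O)NO)n2)c1` differs from compound 3 by hydroxy in place of 2-aminophenyl on an amide-type nitrogen. Among the compounds with values here, the one measured step that bears on this change runs the other way: an at least 11-fold higher number from compound 1 to compound 2 (1.06 log units; beyond the scatter). The second step, a step that the two limits leave unreadable from compound 2 to compound 3, says nothing usable about the ethyl for tert-butyl exchange, so compound 1 remains the closest measured anchor for the hydroxy series.

Reversing the change that produced the large loss between compound 1 and compound 2 is expected to restore potency, so the step of an at least 11-fold lower number from compound 3 to compound 4 (1.06 log units; beyond the scatter) from compound 3 to compound 4 is expected to be a large fall in this assay. Compound 4 is therefore estimated at 2600 nM, with a range of 800 nM to 8000 nM.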

Compound 4, half-maximal inhibitory concentration: 787 nM
Compound 4: the middle estimate sits 3.3-fold (0.52 log units) above what was measured, and the stated range ends above it.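

The change from 2-aminophenyl to hydroxy on the amide-type nitrogen now reads on a second core in this assay, with an at least 38-fold lower number from compound 3 to compound 4 (1.58 log units; beyond the scatter). It runs the same way on both cores: the same change on two cores in this assay, an at least 11-fold higher number (1.06 log units; beyond the scatter) from compound 1 to compound 2 and an at least 38-fold higher number (1.58 log units; beyond the scatter) from compound 4 to compound 3; the limit leaves it open whether they differ The exchange of ethyl for tert-butyl on an oxygen next to a carbonyl group, unreadable among the 2-aminophenyl compounds, can now be read among the hydroxy compounds, with a 3.3-fold lower number from compound 1 to compound 4 (0.52 log units; beyond the scatter).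

Going by these compounds, whether that exchange has any effect among the 2-aminophenyl compounds stays open, as both of them are limits: the limit of > 30000 nM in this assay, at which 2 of the 4 values shown sit. Also open is whether methyl in place of ethyl on that oxygen, or a longer chain carrying the hydroxycarbamoyl group, would shift the number further in this assay.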